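A few compounds are considered here, and "the series" means these few. Any claim that something is new, unique, unknown or untested is made for them only; others in the source may bear on it.

Working notes on the series: in a functional assay on MDA-MB-231 cells (Homo sapiens) for antiproliferative activity, read by MTT assay, with a stated time of 48 h (a higher number here means a weaker inhibitor, a lower number a stronger inhibitor), compound 1 (`COC(=O)/C(=C/c1ccccc1)CN1C(=O)[C@@H](OC)[C@H]1c1ccc(F)cc1`) gives 21800 nM. From the compounds shown here alone, compound 2 (`COC(=O)/C(=C/c1ccccc1)CN1C(=O)[C@@H](OC)[C@H]1c1cccc(Cl)c1`) has no result reported, so its standing is unknown. The next structure is compound 3 (`COC(=O)/C(=C/c1ccccc1)CN1C(=O)[C@@H](OC)[C@H]1c1ccc(Cl)cc1Cl`). The step 2,4-dichlorophenyl in place of 3-chlorophenyl on a saturated ring carbon puts 2,4-dichlorophenyl in place of 3-chlorophenyl on a saturated ring carbon. For the measured compounds named here, the only anchor is compound 1 at 21800 nM, and no measured step is available, so compound 3 is expected to differ from it in this assay by no more than the scatter, in neither direction. The estimated value for compound 3 is 18000 nM, with an expected range of 6000 nM to 50000 nM.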

Compound 3, half-maximal inhibitory concentration: 19000 nM
Estimate against measurement, compound 3: 1.1-fold (0.02 log units) below; the measured number falls inside the stated range.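

In this assay, 2,4-dichlorophenyl in place of 4-fluorophenyl on the saturated ring carbon gives a 1.1-fold lower number from compound 1 to compound 3 (0.06 log units; within the scatter), so at this position the assay does not separate these two substituted phenyl groups, even with a second halogen on the ring. The step from compound 2 to compound 3 cannot be read, as compound 2 has no value. Nothing measured here bears on why the two phenyl groups read alike. From the compounds shown here alone, only halogen-bearing phenyl groups appear at this carbon, so the effect of an amine, a carboxylic acid or a longer chain there remains open.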